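Compound 2 to compound 4: a methoxy replacement

The source may hold more compounds than are shown below. What is called first, only, known or untested is meant among the compounds shown, and "the series" means these compounds.

Measured compounds and their values:
compound 1 (`N#Cc1cnc(NCc2cnccc2C(F)(F)F)cc1NC[C@H]1C[C@H](O)C1`) gives 61%
compound 2 (`CO[C@H]1CC[C@@H](Nc2cc(NCc3cnccc3C(F)(F)F)ncc2C#N)CC1`) gives 1%
compound 3 (`N#Cc1cnc(NCc2cnccc2C(F)(F)F)cc1NC1CCOCC1`) gives 17%

In an ADME assay on S9 fraction from liver (Rattus norvegicus) for metabolic stability, with a stated time of 1 h (a higher number here means that more of the compound is left, a lower number that less of the compound is left), compound 2 has the lowest number of the three (1%). Its nearest neighbour is compound 3 and its furthest is compound 1, both clearly higher. The next step leads to compound 4 (`N#Cc1cnc(NCc2cnccc2C(F)(F)F)cc1N[C@H]1CC[C@@H](n2cncn2)CC1`), and the change is counted here (1H-1,2,4-triazol-1-yl in place of methoxy on a saturated ring carbon). In words, 1H-1,2,4-triazol-1-yl stands in place of methoxy on a saturated ring carbon.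

Going by the values given here, no measured compound carries this new group, so no measured step shows the swap directly. Among the compounds with values here, two measured steps touch compound 2, both through the group on a nitrogen on an aromatic ring. The large one shows a number 60 percentage points lower from compound 1 to compound 2 (beyond the scatter) and the modest one shows a number 16 percentage points higher from compound 2 to compound 3 (beyond the scatter) in the same read-out. With three compounds this is thin evidence, but it shows that this part of the molecule can move this assay well beyond the scatter. Compound 2 leaves almost no room downward at 1% so a modest rise is the more likely outcome.

The expected change is a number 13 percentage points higher from compound 2 to compound 4 (beyond the scatter) as an estimate only. For compound 4 the estimated value is 14% with an expected range from 2% to 40% in this measurement.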

Compound 4, percent of the compound remaining: 44%
Estimate against measurement, compound 4: 30 percentage points below; the whole stated range lies below it.
By their numbers in this assay, from the lowest: compound 2; then compound 3; then compound 4; then compound 1.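

Among the steps shown in this assay, a number 43 percentage points higher from compound 2 to compound 4 (beyond the scatter) is the only one that leaves the six-membered non-aromatic ring of carbon only in place and changes just the group on its saturated ring carbon, whereas the earlier steps replaced the whole group on the nitrogen. That single exchange is printed as large, while replacing the entire 4-methoxycyclohexyl with oxan-4-yl, a number 16 percentage points higher from compound 2 to compound 3 (beyond the scatter), is printed as modest, so this saturated ring carbon, three ring bonds from the ring atom that bears a large group, is by itself a place where the read-out can move well beyond the scatter. Methoxy leaves and 1H-1,2,4-triazol-1-yl enters, with more heavy atoms, more hydrogen-bond acceptors and a new aromatic ring all arriving at once, but no measurement here accounts for the rise.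

The compounds shown leave open whether the step comes from the loss of methoxy or from the arrival of the triazolyl ring. Also open, going by these compounds, is what a hydroxy group, an amine or a 1H-pyrazol-1-yl group on the same saturated ring carbon would give in this assay.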